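Isopropoxy for (2-methoxyethyl)sulfanyl: a first step without precedent

The source may report more compounds than this note shows. Statements on the series, on what has been measured and on what is new or still open speak of the compounds shown alone.

Of the compounds shown here, two have numbers so far. In a functional assay on MV4-11 cells (Homo sapiens) for inhibition, read by resazurin assay, with a stated time of 72 h (on this read-out lower numbers stand for stronger inhibition of growth and higher numbers for weaker inhibition of growth), compound 1 `Oc1ccccc1Nc1nccc(-c2c[nH]c3ccccc23)n1` gives 570 nM. In this assay compound 2 `COCCSc1nc(C)c(-c2ccnc(Nc3ccc(OC)cc3OC)n2)s1` gives 810 nM. These two numbers lie within the usual scatter of each other, so compound 2 stands level with compound 1 and no order can be read between them.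

Compound 3 `COc1ccc(Nc2nccc(-c3sc(OC(C)C)nc3C)n2)c(OC)c1` keeps the rest of compound 2 and changes one group: isopropoxy in place of (2-methoxyethyl)sulfanyl on an aromatic carbon. Isopropoxy replaces (2-methoxyethyl)sulfanyl on an aromatic carbon of a five-membered aromatic ring with 1 nitrogen and 1 sulfur. Among the measured compounds shown here, no step between measured compounds covers this change, and compound 1 differs from compound 2 in more than one place, so the data offer no direct guide to its size or direction. The expectation therefore rests on compound 2 at 810 nM, with a wide margin on both sides. The estimated move, a 1.1-fold lower number from compound 2 to compound 3 (0.03 log units; within the scatter), is expected to stay within the scatter in this assay. For compound 3 the estimated value is 750 nM, with an expected range of 220 nM to 2500 nM.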

Compound 3, concentration for 50% growth inhibition: 8690 nM
Compound 3: middle estimate off by 12-fold (1.06 log units), on the low side; measured number outside the range, above it.
By their numbers in this assay, from the lowest: compounds 1 and 2 (each within the scatter of the next); then compound 3.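

In this assay, this aromatic carbon, next to the ring nitrogen and next to the ring sulfur, proves sensitive to what it carries: isopropoxy in place of (2-methoxyethyl)sulfanyl gives an 11-fold higher number from compound 2 to compound 3 (1.03 log units; beyond the scatter) with the rest of compound 2 unchanged. Among the compounds shown here, this is the first one-place comparison, and it shows that the group here can decide the level of growth inhibition, which compound 1 and compound 2 could not show as an unmatched pair. No measurement at hand explains the size of this step.

The step changes several things at once: the atom joining the group to the ring, the branching, and the presence of the ether oxygen in the chain, so the compounds shown cannot assign the loss to any one of them. Open, as far as these compounds go, is whether 2-methoxyethoxy or isopropylsulfanyl at this carbon would stay close to compound 2 or fall with compound 3, and how a different kind of group, such as an amine like morpholine, would read at this position.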